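A few compounds are considered here, and "the series" means these few. Any claim that something is new, unique, unknown or untested is made for them only; others in the source may bear on it.

Three compounds built on the shared core of compound 1 `CC1(C)[C@H]2CC[C@]1(C)N(Cc1cn(-c3ccccc3F)nn1)C(=O)C2` differ only in the aryl group on the triazole nitrogen. In a functional assay on OVCAR-3 cells (Homo sapiens) for inhibition, read by MTT assay, with a stated time of 24 h (on this read-out lower numbers stand for stronger inhibition and higher numbers for weaker inhibition), compound 1 gives 300 nM. Compound 2 `CC1(C)[C@H]2CC[C@]1(C)N(Cc1cn(-c3ccc(F)cc3)nn1)C(=O)C2` gives 200 nM in this assay, and compound 3 `COc1ccccc1-n1cc(CN2C(=O)C[C@@H]3CC[C@@]2(C)C3(C)C)nn1` gives 140 nM. Compound 2 stands second highest of the three numbers: its nearest neighbour is compound 3, with a 1.4-fold lower number from compound 2 to compound 3 (0.15 log units; within the scatter), and its furthest is compound 1, with a 1.5-fold lower number from compound 1 to compound 2 (0.18 log units; within the scatter).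

Compound 4 `Cc1cccc(-n2cc(CN3C(=O)C[C@@H]4CC[C@@]3(C)C4(C)C)nn2)c1` carries 3-methylphenyl in place of 4-fluorophenyl on an aromatic nitrogen. Among the compounds with values here, the steps that bear on this change are all small: a 1.5-fold lower number from compound 1 to compound 2 (0.18 log units; within the scatter), a 1.4-fold lower number from compound 2 to compound 3 (0.15 log units; within the scatter), and the only one beyond the scatter, a 2.1-fold lower number from compound 1 to compound 3 (0.33 log units; beyond the scatter). Every aryl variation seen so far has moved the number little, so no step beyond the scatter is expected here, in either direction. On that basis the step expected is no change at the digits printed from compound 2 to compound 4 (within the scatter). Compound 4 is therefore expected to give about 200 nM in this assay, within a range from 100 nM to 400 nM.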

Compound 4, half-maximal inhibitory concentration: 160 nM
For compound 4 the middle estimate is 1.3-fold (0.10 log units) above the measured one; the range from low to high includes it.
By their numbers in this assay, from the lowest: compounds 3, 4, 2 and 1 (each within the scatter of the next, the first and the last beyond it).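

In this assay, within the data shown here, 3-methylphenyl is the first aryl group in this set to contain carbon only, and it gives a 1.3-fold lower number from compound 2 to compound 4 (0.10 log units; within the scatter), a 1.1-fold higher number from compound 3 to compound 4 (0.06 log units; within the scatter) and a 1.9-fold lower number from compound 1 to compound 4 (0.27 log units; within the scatter). On the aromatic nitrogen, then, a group with neither the fluorine of the first two compounds nor the oxygen of the methoxy compound stays within the scatter of all three, and the only step beyond the scatter among these four compounds remains a 2.1-fold lower number from compound 1 to compound 3 (0.33 log units; beyond the scatter). No available evidence accounts for how closely these aryl groups lie together.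

Going by these compounds, whether a carboxylic acid or an amine on the phenyl ring, or a longer alkyl chain in place of that ring, would move the number beyond the scatter remains open. On these data alone, it is also open whether 2-methylphenyl or 4-methylphenyl would stay as close to 3-methylphenyl.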